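This account rests on a few compounds, and the source may have more. Where it says the series, first, only, none or still open, it means among the compounds named here.

Values in a toxicity assay on MDCK cells (Canis lupus familiaris) for cytotoxicity, read by CCK-8 assay, with a stated time of 48 h (on this read-out lower numbers stand for higher toxicity in this test and higher numbers for lower toxicity in this test), each of them a limit of the assay and not a number:
Compound 1 (`CCCCOc1ccc(C(=O)NNc2c(Br)cccc2Br)cc1`) gives > 100000 nM
Compound 2 (`CCc1ccc(C(=O)NNc2c(Br)cccc2Br)cc1`) gives > 100000 nM
Compound 3 (`CC(C)(C)c1ccc(C(=O)NNc2c(Br)cccc2Br)cc1`) gives > 100000 nM

Compound 3 stands at > 100000 nM, which is a limit. For the measured compounds named here, it shares that position with the other two compounds, and the series so far comes down to the limit of > 100000 nM in this assay, at which 3 of the 3 values shown sit.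

Compound 4 (`O=C(NNc1c(Br)cccc1Br)c1ccc(Br)cc1`) has bromo in place of tert-butyl on an aromatic carbon, para to a large group: bromo in place of tert-butyl on an aromatic carbon.

Three measured steps also exchange one group on an aromatic carbon. Going by the values given here, the first is a step that the two limits leave unreadable from compound 1 to compound 2. The second is a step that the two limits leave unreadable from compound 1 to compound 3. The third is a step that the two limits leave unreadable from compound 2 to compound 3. Among the compounds with values here, none of them has a readable size, so they give no direction for the new exchange, and no measured compound has yet given a number.

No step beyond the usual scatter is therefore expected in this assay. This expectation rests on compound 3, whose limit is > 100000 nM. The expected step is a number no higher from compound 3 to compound 4 (the limit leaves the size open). For compound 4 the estimate is 100000 nM, with an expected range from 40000 nM to 200000 nM.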

Compound 4, half-maximal cytotoxic concentration: > 100000 nM
Compound 4 gave a limit, no number; the forecaster's own chance of this, stated with the estimate: 80%; the middle value sits exactly at the limit.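

Compound 4 joins compounds 1, 2 and 3, and no step linking it to any of them can be read, because all four compounds share one limit: the limit of > 100000 nM in this assay, at which 4 of the 4 values shown sit.

The compounds shown leave open whether exchanging butoxy, ethyl, tert-butyl or bromo on the aromatic carbon changes the read-out in this assay at all.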